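Swapping the ring-nitrogen ethyl for a benzyl group

A few compounds are considered here, and "the series" means these few. Any claim that something is new, unique, unknown or untested is made for them only; others in the source may bear on it.

Compound 1: `CSc1ccc2c(c1)c(O)c(C(=O)N(C)c1ccccc1)c(=O)n2C`, 100%
Compound 2: `CN(C(=O)c1c(O)c2cc(Oc3ccccc3)ccc2n(C)c1=O)c1ccccc1`, 26%
Compound 3: `CCn1c(=O)c(C(=O)N(C)c2ccccc2)c(O)c2cc(SC)ccc21`, 83%

In a functional assay on the whole organism for inhibition, with Mus musculus as the target, at a dose of 32 mg/kg by the oral route (a lower number here means less inhibition, a higher number more inhibition at the dose given (going by the name of the read-out)), compound 3 stands second highest of the three numbers. Compound 1 sits above it, with a number 17 percentage points lower from compound 1 to compound 3 (beyond the scatter) separating the two, and compound 2 sits far below, as its value shows. The new compound 4 is `CSc1ccc2c(c1)c(O)c(C(=O)N(C)c1ccccc1)c(=O)n2Cc1ccccc1`, and it differs from compound 3 in this way: phenyl in place of methyl on a saturated chain carbon bound to an aromatic nitrogen. Within the data shown here, only one measured step touches the same place, the change from compound 1 to compound 3, which was a number 17 percentage points lower from compound 1 to compound 3 (beyond the scatter). The other step, a number 74 percentage points lower from compound 1 to compound 2 (beyond the scatter), concerns a different position and cannot be read across directly. Since enlarging the group on the saturated chain carbon bound to the aromatic nitrogen has so far lowered the read-out in this assay, and the present change enlarges it again, a further decrease is expected, probably beyond the scatter, with the size uncertain. The estimated step for compound 4 is a number 28 percentage points lower from compound 3 to compound 4 (beyond the scatter). Compound 4 is expected to give about 55%, within a range from 20% to 90%.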

Compound 4, a percentage reported as inhibition, in the whole organism at one dose (the size of the read-out at that dose, not a potency): -66%
Estimate against measurement, compound 4: 121 percentage points above; the measured number lies below the stated range.
By their numbers in this assay, from the lowest: compound 4; then compound 2; then compound 3; then compound 1.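

On the saturated chain carbon bound to the aromatic nitrogen, the change from ethyl to benzyl weighs far more than the earlier step from methyl to ethyl suggested: in this assay phenyl in place of methyl gives a number 149 percentage points lower from compound 3 to compound 4 (beyond the scatter) and phenyl in place of hydrogen gives a number 166 percentage points lower from compound 1 to compound 4 (beyond the scatter) in this series. The read-out does not just shrink here but crosses zero, with compound 4 at -66% as a negative number, and among compound 1, compound 3 and compound 4, which differ only in this place, each larger group gives a lower number. Nothing available explains why this step is so large.

Going by these compounds, whether a longer chain without a ring would also fall this far remains open. So does the effect of an amine or a carboxylic acid at the end of this chain.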